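The source may report more compounds than this note shows. Statements on the series, on what has been measured and on what is new or still open speak of the compounds shown alone.

Measured so far:
- compound 1 `COc1cc2c(Oc3ccc(NC(=O)c4cc(-c5ccccc5F)ccn4)cc3F)ccnc2cc1OCCCN1CCCCC1`: 180 nM
- compound 2 `COc1cc2c(Oc3ccc(NC(=O)c4cc(-c5ccccc5C)ccn4)cc3F)ccnc2cc1OCCCN1CCN(C)CC1`: 240 nM

In a functional assay on MKN-45 cells (Homo sapiens) for cytotoxicity, read by MTT assay, with a stated time of 72 h (on this read-out higher numbers stand for weaker inhibition and lower numbers for stronger inhibition), compound 1 gives 180 nM and compound 2 gives 240 nM. Compound 2 has the higher of the two numbers, but its gap to compound 1 lies within the scatter, so the two cannot be ordered.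

Compound 3 `COc1ccc(-c2ccnc(C(=O)Nc3ccc(Oc4ccnc5cc(OCCCN6CCN(C)CC6)c(OC)cc45)c(F)c3)c2)c(OC)c1` has not been measured. Relative to compound 2 the change is 2,4-dimethoxyphenyl in place of 2-methylphenyl on an aromatic carbon. For the measured compounds named here, no measured pair shows this change, so no step size is available to lean on. The step from compound 2 to compound 3 is expected to be small, a 1.1-fold higher number from compound 2 to compound 3 (0.03 log units; within the scatter), with no direction resolved beyond the scatter. Compound 3 is estimated at 260 nM, between 90 nM and 750 nM.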

Compound 3, half-maximal inhibitory concentration: 330 nM
For compound 3 the middle estimate is 1.3-fold (0.10 log units) below the measured one; measured number inside the range.
By their numbers in this assay, from the lowest: compounds 1, 2 and 3 (each within the scatter of the next).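

In this assay, for the compounds shown here, the step of a 1.4-fold higher number from compound 2 to compound 3 (0.14 log units; within the scatter) is the first single-place comparison, made on the aromatic carbon opposite the ring nitrogen. It shows that 2,4-dimethoxyphenyl can replace 2-methylphenyl at this position without a shift beyond the scatter. No measurement available explains this result.

Compound 1 and compound 2 differ in two places, so the contributions of their aryl groups and side chains remain unseparated. On these data alone, whether an amine or a carboxylic acid on this aryl ring would shift the number beyond the scatter remains open.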